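Methoxy for fluoro on the salicylanilide ring

The source may report more compounds than this note shows. Statements on the series, on what has been measured and on what is new or still open speak of the compounds shown alone.

Compound 2 `O=C(Nc1cc(C(F)(F)F)cc(C(F)(F)F)c1)c1cc(F)ccc1O` is the reference point. For the measured compounds named here, in an assay for inhibition of transmembrane protease serine 4 (Homo sapiens), read by fluorescence (on this read-out lower numbers stand for stronger inhibition and higher numbers for weaker inhibition), compound 2 gives 29000 nM, the only outright number obtained so far. Compound 1 `O=C(Nc1cc(C(F)(F)F)cc(C(F)(F)F)c1)c1ccccc1O` reaches only the limit of the assay, > 100000 nM, so no number stands for it. Going by the values given here, the single measured step, an at least 3.4-fold lower number from compound 1 to compound 2 (0.53 log units; beyond the scatter), is therefore known only as a lower bound, and its cause is not told by anything measured beyond (the limit of > 100000 nM in this assay, at which 1 of the 2 values shown sits).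

Compound 3 `COc1ccc(O)c(C(=O)Nc2cc(C(F)(F)F)cc(C(F)(F)F)c2)c1` carries the change (methoxy in place of fluoro on an aromatic carbon), methoxy in place of fluoro on an aromatic carbon. The measured step concerns the same aromatic carbon, but it compares fluoro with hydrogen, not methoxy with fluoro; it shows that a substituent there can lower the number, and nothing more. Any step in this assay is therefore expected to stay small, without a clear direction. The expected step is a 1.0-fold higher number from compound 2 to compound 3 (0.01 log units; within the scatter). Compound 3 is estimated at 30000 nM, with a range from 8000 nM to 100000 nM.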

Compound 3, half-maximal inhibitory concentration: 29000 nM
For compound 3 the middle estimate is 1.0-fold (0.01 log units) above the measured one, and the stated range covers the measured number.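

In this assay, the exchange of fluoro for methoxy on this aromatic carbon, para to a hydroxy group, reads as no change at the digits printed from compound 2 to compound 3 (within the scatter), so the two groups are not told apart here, although methoxy brings a hydrogen-bond acceptor and fluoro does not. Compound 1 stands at a limit of the assay, > 100000 nM, and this is not a number. The step with methoxy in place of hydrogen reads as an at least 3.4-fold lower number from compound 1 to compound 3 (0.53 log units; beyond the scatter), the same bound as with fluoro, so a lower number with a substituent on this carbon is no longer tied to fluoro alone, while the true size of the step stays unknown: the limit of > 100000 nM in this assay, at which 1 of the 3 values shown sits.

The compounds shown leave open whether an amine, a carboxylic acid or a longer chain such as ethoxy on this carbon would stay with compound 2 and compound 3 or move well away from them. They also hold the hydroxy group and both trifluoromethyl groups fixed, so what each of these contributes to the reading cannot be told from this set.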